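The source may hold more compounds than are shown below. What is called first, only, known or untested is meant among the compounds shown, and "the series" means these compounds.

Compound 1 `COc1cc(N(C)C(=O)c2cccc([N+](=O)[O-])c2)cc(OC)c1OC` carries an amide that joins the shared core to a ring bearing a nitro group. In a functional assay on Daoy cells (Homo sapiens) for cytotoxicity, read by MTT assay, with a stated time of 72 h (on this read-out higher numbers stand for weaker inhibition and lower numbers for stronger inhibition), compound 1 gives >= 125000 nM, which is a limit of the assay rather than a number. Compound 2 `COc1cc(N(C)C(=O)N(C)c2cccc([N+](=O)[O-])c2)cc(OC)c1OC` differs from compound 1 in its core; the difference between the two cores is not broken down here. In this assay compound 2 also gives >= 125000 nM, again a limit. Compound 3 `COc1cc(N(C)C(=O)N(C)c2cccc(F)c2)cc(OC)c1OC` arises from compound 2 by the change (fluoro in place of nitro on an aromatic carbon). In this assay compound 3 gives >= 125000 nM, once more a limit. The step that the two limits leave unreadable from compound 2 to compound 3 therefore cannot be sized, because of the limit of >= 125000 nM in this assay, at which 3 of the 3 values shown sit.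

Compound 4 `COc1cc(N(C)C(=O)c2cccc(F)c2)cc(OC)c1OC` is not yet measured and arises from compound 1 by the same change, (fluoro in place of nitro on an aromatic carbon). For compound 4 in this assay the expected step is a number no higher from compound 1 to compound 4 (the limit leaves the size open), resting on compound 1 at >= 125000 nM and on the fact that compound 2 and compound 3 both sit at the same limit. The estimate for compound 4 is 125000 nM, between 60000 nM and 300000 nM, with the outcome expected to be another limit.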

Compound 4, half-maximal inhibitory concentration: >= 125000 nM
Compound 4: no number, only a limit (the forecaster's own chance of this, stated with the estimate: 85%); the middle value sits exactly at the limit.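

No step can be read between compound 1 and compound 4, because the two compounds sit at the same limit rather than at numbers: the limit of >= 125000 nM in this assay, at which 4 of the 4 values shown sit.

The compounds shown leave open how far each of the four lies from that limit, and whether fluoro in place of nitro on an aromatic carbon alters the read-out at all.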